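The compounds below may be only part of what the source reports. "The series", "measured", "known", "first", "only" and "open" are said of these compounds alone.

Compound 1 `COC(CN(c1ccccc1CO)S(=O)(=O)c1ccc([N+](=O)[O-])cc1)n1ccc(=O)[nH]c1=O`: 45800 nM
Compound 2 `COC(CN(c1ccccc1CO)S(=O)(=O)c1ccc([N+](=O)[O-])cc1)n1cnc2c(Cl)ncnc21`: 18700 nM
Compound 3 `COC(CN(c1ccccc1CO)S(=O)(=O)c1ccccc1[N+](=O)[O-])n1cnc2c(Cl)ncnc21`: 11300 nM; 3250 nM (2 entries)

In a functional assay on MCF7 cells (Homo sapiens) for antiproliferative activity (on this read-out higher numbers stand for weaker inhibition and lower numbers for stronger inhibition), compound 1 stands highest of the two single numbers, with compound 2 nearest after a 2.4-fold lower number from compound 1 to compound 2 (0.39 log units; beyond the scatter). Compound 4 `COC(CN(c1ccccc1CO)S(=O)(=O)c1ccccc1[N+](=O)[O-])n1ccc(=O)[nH]c1=O` differs from compound 1 by 2-nitrophenyl in place of 4-nitrophenyl on a sulfonyl sulfur. Among the measured compounds shown here, no measured step covers this change directly; the step from compound 1 to compound 2 concerns the other position of the shared core. Compound 2 and compound 3 differ in the same way on their own core, and there compound 2 gives 18700 nM while compound 3 gives (the several entries of compound 3 in this assay, 11300 nM; 3250 nM (2 entries)). The step from compound 1 to compound 4 in this assay is therefore expected to be a 2.3-fold lower number from compound 1 to compound 4 (0.36 log units; beyond the scatter). Compound 4 is estimated at 20000 nM, within 6000 nM to 60000 nM.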

Compound 4, half-maximal inhibitory concentration: 64800 nM
Estimate against measurement, compound 4: 3.2-fold (0.51 log units) below, and the stated range ends below it.
By their numbers in this assay, from the lowest: compound 2; then compounds 1 and 4 (each within the scatter of the next).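

Among the compounds shown here, on the core of compound 1, 2-nitrophenyl in place of 4-nitrophenyl on a sulfonyl sulfur gives in this assay a 1.4-fold higher number from compound 1 to compound 4 (0.15 log units; within the scatter) and so no step that stands clear of the scatter. The lower numbers that compound 3 shows against compound 2 at 18700 nM therefore do not carry over to this core, and the same change on the two cores does not read alike: the several entries of compound 3 in this assay, 11300 nM; 3250 nM (2 entries).

Still open, from the compounds shown here alone, is whether an amine or a carboxylic acid in place of the nitro group would move the number on either core. The spread among the entries of compound 3 also leaves the size of the step on its core unsettled.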